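Furan-2-yl in Place of Methoxyphenyl: an Expected Step

A few compounds are considered here, and "the series" means these few. Any claim that something is new, unique, unknown or untested is made for them only; others in the source may bear on it.

Of the compounds shown here, three sharing one core have been tested in a functional assay on U-251 cells (Homo sapiens) for inhibition, read by sulforhodamine B assay, with a stated time of 48 h; on this read-out lower numbers stand for stronger inhibition of growth and higher numbers for weaker inhibition of growth. Compound 1 `CC1=CC[C@H](C(C)(C)N=C=S)CC1` gives 29100 nM. Compound 2 `COc1ccc(/C=N/NC(=S)NC(C)(C)[C@H]2CC=C(C)CC2)cc1` gives 11400 nM in this assay. Compound 3 `CC1=CC[C@H](C(C)(C)NC(=S)N/N=C/c2cccc([N+](=O)[O-])c2)CC1` reaches only a limit of this assay, > 100000 nM. Of the two numbers available, compound 2 stands lowest, with compound 1 the nearest at a gap beyond the usual scatter. The third value, that of compound 3, is a limit and not a number (the limit of > 100000 nM in this assay, at which 1 of the 3 values shown sits).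

Compound 4 `CC1=CC[C@H](C(C)(C)NC(=S)N/N=C/c2ccco2)CC1` has not yet been measured in this assay. It differs from compound 2 in one place: furan-2-yl in place of 4-methoxyphenyl on a carbon with a double bond to nitrogen. Among the measured compounds shown here, no pair of measured compounds shows this exchange, and the only other group tried at that position, in compound 3, gave a limit rather than a number. The step of a 1.9-fold higher number from compound 2 to compound 4 (0.29 log units; within the scatter) is therefore expected to be modest and to run toward weaker inhibition of growth, though a result within the scatter would not surprise. Compound 4 is estimated at 22000 nM, with a likely range from 7000 nM to 80000 nM in this assay.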

Compound 4, concentration for 50% growth inhibition: 9700 nM
Compound 4: middle estimate off by 2.3-fold (0.36 log units), on the high side; measured number inside the range.
By their numbers in this assay, from the lowest: compounds 4 and 2 (each within the scatter of the next); then compound 1. At a limit, above all of these: compound 3.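

In this assay, furan-2-yl in place of 4-methoxyphenyl gives a 1.2-fold lower number from compound 2 to compound 4 (0.07 log units; within the scatter) and so leaves the two compounds indistinguishable on this read-out. Among the compounds shown here, this is the first exchange at this position, on a carbon with a double bond to nitrogen, that can be read as a step between two numbers, and it shows that growth inhibition in this range does not depend on keeping the six-membered aromatic ring of carbon only: a five-membered aromatic ring with 1 hetero atom and 5 heavy atoms serves as well as the 8 heavy atoms of 4-methoxyphenyl. Compound 3, with a different group at the same position, remains a limit and not a number: the limit of > 100000 nM in this assay, at which 1 of the 4 values shown sits.

The compounds shown leave open how a pyridine ring, a thiophene ring or an unsubstituted phenyl group would fare at this position, and so whether the match between the two groups tested extends to other aromatic rings. They also leave open whether an open-chain group such as an alkyl chain or an amine can take the place of the ring at all.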